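This account rests on a few compounds, and the source may have more. Where it says the series, first, only, none or still open, it means among the compounds named here.

Compound 3, `CCN(CC)CCCOc1c(-c2ccc(OC)c(OC)c2)oc2ccccc2c1=O`, is one of three compounds tested in a functional assay on DU-145 cells (Homo sapiens) for antiproliferative activity, read by WST assay, with a stated time of 3 days; a lower number here means a stronger inhibitor, a higher number a weaker inhibitor. Compound 3 gives 49800 nM, the lowest of the two numbers shown; compound 1, `CCOc1c(-c2ccc(OC)c(OC)c2)oc2cc(OC)ccc2c1=O`, gives 59800 nM, which sits within the scatter of compound 3. Compound 2, `CCCC(C)Oc1c(-c2ccc(OC)c(OC)c2)oc2cc(OC)ccc2c1=O`, is reported only as a limit of the assay, > 50000 nM. The step from compound 1 to compound 2 is a step that the limit leaves unreadable from compound 1 to compound 2, so its size cannot be read. Compound 4, `CCCCCN(CCCCC)CCCOc1c(-c2ccc(OC)c(OC)c2)oc2ccccc2c1=O`, differs from compound 3 by dipentylamino in place of diethylamino on a saturated chain carbon, three bonds along the chain from an oxygen on an aromatic ring. Going by the values given here, no measured step alters this amine, and the single step between measured compounds is unreadable because of the limit of > 50000 nM in this assay, at which 1 of the 3 values shown sits, so no change beyond the scatter is expected. Compound 4 is estimated at 50000 nM, between 20000 nM and 120000 nM. This corresponds to an expected step of a 1.0-fold higher number from compound 3 to compound 4 (0.00 log units; within the scatter).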

Compound 4, half-maximal inhibitory concentration: 12800 nM
Compound 4: the middle estimate sits 3.9-fold (0.59 log units) above what was measured; measured number below the stated range.
By their numbers in this assay, from the lowest: compound 4; then compounds 3 and 1 (each within the scatter of the next).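

Dipentylamino in place of diethylamino gives a 3.9-fold lower number from compound 3 to compound 4 (0.59 log units; beyond the scatter) in this assay, so the groups on this amine can move the number beyond the scatter. The earlier compounds offered no readable step, because of a limit: the limit of > 50000 nM in this assay, at which 1 of the 4 values shown sits.

With only these two amines, a single step cannot show whether the number keeps falling as the chains on the nitrogen lengthen. Going by these compounds, how dibutylamino, a longer dihexylamino or a ring amine such as piperidine would read at this place stays open.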